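Trifluoromethyl for Trifluoromethoxy in an Anilino-Styrene Series

A few compounds are considered here, and "the series" means these few. Any claim that something is new, unique, unknown or untested is made for them only; others in the source may bear on it.

Four compounds sharing one core are compared in a functional assay on SEM cells (Homo sapiens) for cytotoxicity, with a stated time of 72 h; on this read-out higher numbers stand for an effect only at larger amounts of compound and lower numbers for an effect already at smaller amounts. Compound 1 `C=C[C@@](C)(/C=C/c1ccc(Nc2cccc(OC(F)(F)F)c2)cc1)CCC=C(C)C` carries a trifluoromethoxy group on the anilino ring. In this assay compound 1 gives only a limit, > 36600 nM. Compound 2 `C=C[C@@](C)(/C=C/c1ccc(Nc2ccc(OC(F)(F)F)cc2)cc1)CCC=C(C)C` has the same atoms joined differently; the difference between the two cores is not broken down here. In this assay compound 2 likewise gives only a limit, > 36600 nM. Compound 3 `C=C[C@@](C)(/C=C/c1ccc(Nc2ccc(C(F)(F)F)cc2)cc1)CCC=C(C)C` differs from compound 2 by trifluoromethyl in place of trifluoromethoxy on an aromatic carbon. In this assay compound 3 also gives only a limit, > 36600 nM. The step that the two limits leave unreadable from compound 2 to compound 3 therefore cannot be sized, because of the limit of > 36600 nM in this assay, at which 3 of the 3 values shown sit.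

Compound 4 `C=C[C@@](C)(/C=C/c1ccc(Nc2cccc(C(F)(F)F)c2)cc1)CCC=C(C)C` differs from compound 1 by trifluoromethyl in place of trifluoromethoxy on an aromatic carbon. This is the same kind of change as that from compound 2 to compound 3, but not the same: in one the group is para to a large group, in the other meta to a large group. Among the measured compounds shown here, since no measured step is readable, compound 4 is expected to remain at the limit, a step that the limit leaves unreadable from compound 1 to compound 4 from compound 1. The estimate for compound 4 in this assay is 60000 nM.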

Compound 4, half-maximal effective concentration: > 36600 nM
Compound 4: a limit, no number; the forecaster's own chance of this, stated with the estimate: 90%; the middle value does not contradict the limit.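

Among the compounds shown here, compound 1 and compound 4 each give only a limit in this assay, so trifluoromethyl in place of trifluoromethoxy on an aromatic carbon yields no step that can be read, here as between compound 2 and compound 3: the limit of > 36600 nM in this assay, at which 4 of the 4 values shown sit. The compounds shown leave open how the four compare in potency and whether the two groups differ in effect at all.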